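Swapping Chloro for Hydrogen on Compound 2

This account rests on a few compounds, and the source may have more. Where it says the series, first, only, none or still open, it means among the compounds named here.

Compound 1 `COC(=O)c1ccc2[nH]cc(C3(c4c[nH]c5ccc(C(=O)OC)cc45)C(=O)Nc4ccccc43)c2c1`: > 100000 nM (a limit)
Compound 2 `O=C1Nc2ccc(Cl)cc2C1(c1c[nH]c2ccc(Br)cc12)c1c[nH]c2ccc(Br)cc12`: > 100000 nM (a limit)

Both compounds were tested in a functional assay on MDA-MB-231 cells (Homo sapiens) for cytotoxicity, read by MTT assay, with a stated time of 48 h; a higher number here means a weaker inhibitor, a lower number a stronger inhibitor. Compound 1 gives > 100000 nM, which is a limit of the assay and not a number. Compound 2 gives > 100000 nM, again a limit and not a number. For the measured compounds named here, compound 2 therefore has no exact position on the scale, and it shares its reading with the only other compound tested: the limit of > 100000 nM in this assay, at which 2 of the 2 values shown sit.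

The next compound, compound 3 `O=C1Nc2ccccc2C1(c1c[nH]c2ccc(Br)cc12)c1c[nH]c2ccc(Br)cc12`, differs from compound 2 in one place: hydrogen in place of chloro on an aromatic carbon. Hydrogen stands in place of chloro on an aromatic carbon. Going by the values given here, no pair of measured compounds differs in just one place, so the size of such a change has not been seen directly in this assay. With both readings at the same limit, only a small change is expected, and it may not exceed the usual scatter. The expected change is an at least 1.2-fold lower number from compound 2 to compound 3 (0.09 log units; that floor lies within the scatter). Compound 3 may well return only a limit too. For compound 3, the estimated value is 80000 nM, with an expected range from 15000 nM to 200000 nM.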

Compound 3, half-maximal inhibitory concentration: 9950 nM
Compound 3: middle estimate off by 8.0-fold (0.91 log units), on the high side; the whole stated range lies above it.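

Taking the chloro group off this aromatic carbon and leaving hydrogen there gives an at least 10-fold lower number from compound 2 to compound 3 (1.00 log units; beyond the scatter) in this assay and so shows that what sits at this position can move the reading beyond the scatter. For the compounds shown here, compound 3 is also the first compound here with an exact reading (9950 nM) rather than a limit, which gives the series a fixed point on the scale against which later single changes can be read. The true size of the step remains unknown and the printed figure is only a floor, because compound 2 gives a limit and not a number: the limit of > 100000 nM in this assay, at which 2 of the 3 values shown sit.

The compounds shown leave open whether hydrogen is special at this position or whether another group on the same aromatic carbon, such as a methoxy group or an amine, would give a similar reading or a different one. They also leave open whether the same swap of chloro for hydrogen would lower the number to a similar degree on a core carrying other groups in place of the bromo groups.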